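The source may hold more compounds than are shown below. What is called first, only, known or untested is meant among the compounds shown, and "the series" means these compounds.

For the measured compounds named here, compound 3 `CCS(=O)(=O)Nc1cc(-c2ccc3ncnc(Nc4ccc(OC(F)(F)F)cc4)c3c2)cnc1OC` gives 22400 nM in a functional assay on SNU-638 cells (Homo sapiens) for cytotoxicity, read by sulforhodamine B assay, with a stated time of 72 h (on this read-out higher numbers stand for weaker inhibition and lower numbers for stronger inhibition), the highest of the three numbers measured so far: compound 1 `CCS(=O)(=O)Nc1cc(-c2ccc3ncnc(Nc4ccc(F)cc4)c3c2)cnc1OC` gives 2400 nM and compound 2 `CCS(=O)(=O)Nc1cc(-c2ccc3ncnc(Nc4ccc(F)cc4F)c3c2)cnc1OC` gives 2050 nM, and both gaps, a 9.3-fold higher number from compound 1 to compound 3 (0.97 log units; beyond the scatter) and an 11-fold higher number from compound 2 to compound 3 (1.04 log units; beyond the scatter), lie beyond the scatter. Compound 4 `CCS(=O)(=O)Nc1cc(-c2ccc3ncnc(Nc4cccc(C(=O)OC)c4)c3c2)cnc1OC` differs from compound 3 in one place: 3-(methoxycarbonyl)phenyl in place of 4-(trifluoromethoxy)phenyl on a nitrogen on an aromatic ring. Going by the values given here, no measured step touches a methoxycarbonyl group, so the guide is indirect: since the step of a 9.3-fold higher number from compound 1 to compound 3 (0.97 log units; beyond the scatter) raised the number when trifluoromethoxy replaced fluoro, taking the trifluoromethoxy group away again is expected to lower the number, though not necessarily all the way back. Compound 4 is therefore expected to come in near 4500 nM, between 1500 nM and 14000 nM, an expected step of a 5.0-fold lower number from compound 3 to compound 4 (0.70 log units; beyond the scatter).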

Compound 4, half-maximal inhibitory concentration: 1120 nM
Estimate against measurement, compound 4: 4.0-fold (0.60 log units) above, outside the stated range (below it).
By their numbers in this assay, from the lowest: compounds 4, 2 and 1 (each within the scatter of the next, the first and the last beyond it); then compound 3.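

With 3-(methoxycarbonyl)phenyl on the nitrogen, the high number of compound 3 is lost: a 20-fold lower number from compound 3 to compound 4 (1.30 log units; beyond the scatter). Fluorine on this ring is therefore not needed to keep the number low, since a 1.8-fold lower number from compound 2 to compound 4 (0.26 log units; within the scatter) and a 2.1-fold lower number from compound 1 to compound 4 (0.33 log units; beyond the scatter). No measurement here explains why the number changes.

The step from compound 3 to compound 4 swaps the group and moves it on the ring at once, so these two changes cannot be separated. From the compounds shown here alone, whether a carboxylic acid or an amide in place of the methyl ester would keep this number also stays open.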